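A few compounds are considered here, and "the series" means these few. Any claim that something is new, unique, unknown or untested is made for them only; others in the source may bear on it.

Compound 1 `Nc1scc(CN2CCN(c3ccc([N+](=O)[O-])cc3)CC2)c1C(=O)c1ccc(Cl)cc1`: 2%
Compound 2 `Nc1scc(CN2CCN(c3cccc(F)c3)CC2)c1C(=O)c1ccc(Cl)cc1`: 4%

Of the compounds shown here, two sharing one core have been tested in an assay on CHO cells for displacement of a labelled ligand from adenosine receptor A3 (Homo sapiens), read by scintillation counting, with a stated time of 120 min, tested at 10 uM; a lower number here means less inhibition, a higher number more inhibition at the concentration tested (going by the name of the read-out). Compound 1 gives 2%, and compound 2 gives 4%. For the measured compounds named here, the one measured step, a number 2 percentage points higher from compound 1 to compound 2 (within the scatter), shows that swapping the group on the amine nitrogen in the ring barely moved the number; both values sit near the bottom of the scale, and compound 2 stands within the scatter of compound 1.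

Compound 3 `Nc1scc(CN2CCN(c3ccccc3F)CC2)c1C(=O)c1ccc(Cl)cc1` is not yet measured. It differs from compound 2 only as follows: 2-fluorophenyl in place of 3-fluorophenyl on an amine nitrogen in a ring. Going by the values given here, the only step that bears on this position is the one from compound 1 to compound 2, and it was within the scatter. Moving the fluorine around the ring is therefore expected to give no step beyond the scatter, so no change at the digits printed from compound 2 to compound 3 (within the scatter) is expected to be small. In this assay compound 3 is expected to give 4%, with a range from -6% to 15%.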

Compound 3, a percentage reported as inhibition, at one concentration (the size of the read-out at that concentration, not a potency): 0%
For compound 3 the middle estimate is 4 percentage points above the measured one; low and high end bracket the measured number.
By their numbers in this assay, from the lowest: compounds 3, 1 and 2 (each within the scatter of the next).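

Moving the fluorine gives a number 4 percentage points lower from compound 2 to compound 3 (within the scatter), so in this assay the shift from 3-fluorophenyl to 2-fluorophenyl on the ring amine nitrogen cannot be told apart from repeat-measurement noise. The comparison with the nitro compound gives a number 2 percentage points lower from compound 1 to compound 3 (within the scatter), so 2-fluorophenyl and 4-nitrophenyl cannot be told apart here either, and all three compounds now stand within the scatter of one another at the low end of the scale. No measurement shown here offers an explanation for these numbers.

Still open, going by these compounds, is whether any other group on this nitrogen, such as benzyl, methyl or a phenyl carrying a carboxylic acid, would lift the number clear of the scatter. With all values this low, these compounds also cannot show whether fluorine placement would matter on a compound with a higher number.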